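From compound 2 to compound 4: notes at the limit

The source may report more compounds than this note shows. Statements on the series, on what has been measured and on what is new or still open speak of the compounds shown alone.

In an ADME assay on MIA PaCa-2 cells (Homo sapiens) for cytotoxicity, read by MTT assay, with a stated time of 72 h (on this read-out lower numbers stand for stronger inhibition and higher numbers for weaker inhibition), compound 2 `COc1ccc(C2=C(c3cc(OC)c(OC)c(OC)c3)C(=O)CC2O)cc1O` gives > 100 ug/mL, which is a limit and not a number. Compound 3 `COc1ccc(C2=C(c3cc(OC)c(OC)c(OC)c3)C(=O)CC2O)cc1` gives > 100 ug/mL, also a limit. Compound 4 `COc1ccc(C2=C(c3cc(OC)c(OC)c(OC)c3)C(=O)CC2O[SiH2]C(C)(C)C)cc1O` carries a group of 5 heavy atoms (4 carbon, 1 silicon; no ring) in place of a hydrogen atom, on an oxygen on a saturated carbon. Compound 1 `COc1ccc(C2=C(c3cc(OC)c(OC)c(OC)c3)C(=O)CC2O[SiH2]C(C)(C)C)cc1OC`, with the same group on that oxygen, gives > 100 ug/mL, again a limit. All readings so far stand at the limit of > 100 ug/mL in this assay, at which 3 of the 3 values shown sit. Among the measured compounds shown here, the one measured step, a step that the two limits leave unreadable from compound 2 to compound 3, offers no size to carry over. No step beyond the scatter is therefore expected in this assay, and no direction can be assigned. The expected change is a step that the limit leaves unreadable from compound 2 to compound 4. Compound 4 is estimated at 120 ug/mL, with an expected range of 50 ug/mL to 300 ug/mL, and will most likely be reported only as a limit.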

Compound 4, half-maximal inhibitory concentration: 55 ug/mL
The estimate for compound 4 lay 2.2-fold (0.34 log units) above the measured number; measured number inside the range.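

In this assay, a group of 5 heavy atoms (4 carbon, 1 silicon; no ring) in place of a hydrogen atom, on an oxygen on a saturated carbon, gives an at least 1.8-fold lower number from compound 2 to compound 4 (0.25 log units; that floor lies within the scatter). With that group kept, hydrogen in place of methyl on an oxygen on an aromatic ring gives an at least 1.8-fold lower number from compound 1 to compound 4 (0.25 log units; that floor lies within the scatter). Compound 4 alone carries both that group and the aromatic hydroxy, and it alone gives a number rather than a limit: the limit of > 100 ug/mL in this assay, at which 3 of the 4 values shown sit.

Going by these compounds, the true size of both steps stays open, since only floors can be read. Also open, on these data alone, is whether an acetyl group or a longer chain on that oxygen, or an amine in place of the aromatic hydroxy, would give a number.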